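The compounds below may be only part of what the source reports. "The series", "measured", "known", "first", "only" and "open" are said of these compounds alone.

Measured compounds:
- Compound 1 `O=[N+]([O-])c1ccc(-c2nn(-c3ccccc3)cc2-c2nnc(-c3ccccc3)o2)cc1`: 74.3 mg/kg
- Compound 2 `COc1ccc(-c2nn(-c3ccccc3)cc2-c2nnc(-c3ccncc3)o2)cc1`: "not determined" (no result reported)

The series is judged in a functional assay on the whole organism for inhibition, with Rattus norvegicus as the target, read by paw edema, with stated times of 1 h and 2 h; on this read-out higher numbers stand for an effect only at larger amounts of compound and lower numbers for an effect already at smaller amounts. In this assay compound 1 gives 74.3 mg/kg. Compound 2 shares the same core, but in this assay compound 2 stands at "not determined" (no result reported), so there is no single number on which its position can be fixed. Compound 3 `O=[N+]([O-])c1ccc(-c2nn(-c3ccccc3)cc2-c2nnc(-c3ccncc3)o2)cc1` is the next compound to be measured. It differs from compound 2 in one place: nitro in place of methoxy on an aromatic carbon. With no number for compound 2, the size of the step from compound 2 to compound 3 in this assay cannot be stated in either direction, nor can it be set against the scatter. Compound 1 carries the same nitrophenyl group as compound 3 and is the only point of reference in hand. Compound 3 is therefore expected to fall near 70 mg/kg, with a range from 30 mg/kg to 160 mg/kg, an estimate resting on compound 1 and its value of 74.3 mg/kg.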

Compound 3, dose for half-maximal effect: 72.6 mg/kg
Compound 3: the middle estimate sits 1.0-fold (0.02 log units) below what was measured; the measured number falls inside the stated range.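

In this assay, the series now holds its first readable comparison: with the 4-nitrophenyl group kept, pyridin-4-yl in place of phenyl on an aromatic carbon gives a 1.0-fold lower number from compound 1 to compound 3 (0.01 log units; within the scatter), so the two groups cannot be told apart at this position in this setting. The change from 4-methoxyphenyl to 4-nitrophenyl cannot be read, since compound 2 has no number, and the result therefore says nothing about the effect of nitro against methoxy. No measurement is at hand that would account for the close agreement of the two nitro compounds.

The compounds shown leave open whether phenyl and pyridin-4-yl would also stay within the scatter of each other with a 4-methoxyphenyl group on the core. They also leave open whether an amine or a carboxylic acid on the same aromatic carbon, or a longer chain such as butoxy there, would move the number in this assay beyond the scatter.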